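The source may hold more compounds than are shown below. What is called first, only, known or untested is meant among the compounds shown, and "the series" means these compounds.

Measured so far:
- compound 1 `Cc1c(C)n(C(=O)c2ccc(O)c(C#N)c2)c2ccccc12`: 10800 nM
- compound 2 `N#Cc1cc(C(=O)N2CS(=O)(=O)c3ccccc32)cc(C2CC2)c1O`: 19200 nM

Both compounds were tested in an assay on tissue (RPTEC cells) for inhibition of solute carrier family 22 member 12 (Homo sapiens), read by scintillation counting, with stated times of 15 min and 2 h; a lower number here means a stronger inhibitor, a higher number a weaker inhibitor. In this assay compound 1 gives 10800 nM, and compound 2 gives 19200 nM. Among the compounds with values here, of these two numbers, the one for compound 2 is the larger, but its gap to compound 1 lies within the usual scatter of repeated measurements, so the two compounds cannot be told apart on this evidence. Both are weak inhibitors by the standard of this read-out.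

The next compound, compound 3 `CCc1cc(C(=O)N2CS(=O)(=O)c3ccccc32)cc(C#N)c1O`, shares the core of compound 2 and differs from it in one place: ethyl in place of cyclopropyl on an aromatic carbon. Within the data shown here, no measured pair in this set shows what such a swap does, so there is nothing to lean on except the small size of the change. A step of this kind is expected to stay within the scatter, with no clear direction in this assay. For compound 3 the expected step from compound 2 is a 1.0-fold lower number from compound 2 to compound 3 (0.00 log units; within the scatter). Compound 3 is therefore estimated to give about 19000 nM in this assay, with a likely range from 8000 nM to 45000 nM.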

Compound 3, half-maximal inhibitory concentration: > 100000 nM
Compound 3 was reported as a limit (the forecaster's own chance of this, stated with the estimate: 10%); middle value at least 5.2-fold (0.72 log units) away from the limit.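

On the aromatic carbon ortho to a hydroxy group, ethyl in place of cyclopropyl gives an at least 5.2-fold higher number from compound 2 to compound 3 (0.71 log units; beyond the scatter) in this assay. Within the data shown here, this is the first comparison here between compounds that differ in one place, and it shows that the number at this position can move beyond the scatter even when one small carbon group replaces another, with neither group carrying a hydrogen-bond donor, an acceptor or a charge. The number for compound 3 is a limit of the assay rather than a measured value, so this pair gives only a lower bound on the size of the step: the limit of > 100000 nM in this assay, at which 1 of the 3 values shown sits.

This single pair cannot separate the loss of the three-membered ring from the change in carbon count, since both happen in the same swap. The compounds shown also leave open how this aromatic carbon would respond to isopropyl, which has no ring but the same number of carbons as cyclopropyl, or to a longer chain, an amine or a carboxylic acid.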